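Amide nitrogen substituent in the thiazolidinedione series

The compounds below may be only part of what the source reports. "The series", "measured", "known", "first", "only" and "open" are said of these compounds alone.

Compound 2 `O=C(COc1ccc(/C=C2\SC(=O)NC2=O)cc1)Nc1nc2ccccc2s1` is known in a functional assay on HepG2 cells (Homo sapiens) for cytotoxicity, read by sulforhodamine B assay, with a stated time of 48 h (a higher number here means a weaker inhibitor of growth, a lower number a stronger inhibitor of growth), only by a limit. In this assay compound 2 gives < 100000 nM, a limit of the assay rather than a number. Compound 1 `Cc1cnc(NC(=O)COc2ccc(/C=C3\SC(=O)NC3=O)cc2)s1` in this assay likewise gives < 100000 nM, also a limit. The step that the two limits leave unreadable from compound 1 to compound 2 therefore cannot be read; what the two measurements share is the limit of < 100000 nM in this assay, at which 2 of the 2 values shown sit. Compound 3 `O=C(COc1ccc(/C=C2\SC(=O)NC2=O)cc1)Nc1ncc([N+](=O)[O-])s1` differs from compound 2 by 5-nitro-1,3-thiazol-2-yl in place of 1,3-benzothiazol-2-yl on an amide-type nitrogen. No measured step sizes this change, so no direction beyond the scatter is expected. Compound 3 is expected at 30000 nM, within 5000 nM to 100000 nM. The expected step is a step that the limit leaves unreadable from compound 2 to compound 3.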

Compound 3, concentration for 50% growth inhibition: < 100000 nM
Compound 3 ended at the assay's limit; the forecaster's own chance of this, stated with the estimate: 40%; the middle value lies beyond the limit too.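

Compound 1, compound 2 and compound 3 all sit at a limit of this assay, so no step among them can be read: the limit of < 100000 nM in this assay, at which 3 of the 3 values shown sit.

From the compounds shown here alone, whether their amide nitrogen substituents differ at all in growth inhibition remains open.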